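The source may hold more compounds than are shown below. What is called first, only, known or untested is meant among the compounds shown, and "the series" means these compounds.

Measured compounds:
compound 1 `O=C(O)CCCOc1cc(-c2ccccc2)cc(-c2ccccc2)n1` gives 300 nM in an assay on cell membranes from spleen (Cavia porcellus) for binding affinity to leukotriene B4 receptor 1 (Homo sapiens); on this read-out higher numbers stand for weaker inhibition and lower numbers for stronger inhibition
compound 2 `O=C(O)CCCCOc1cc(-c2ccccc2)cc(-c2ccccc2)n1` gives 50 nM in this assay
compound 3 `CC(CCCCOc1cc(-c2ccccc2)cc(-c2ccccc2)n1)C(=O)O` gives 4 nM in this assay

Compound 3 holds the lowest number of the three in this assay; the nearest is compound 2, with the step of a 13-fold lower number from compound 2 to compound 3 (1.10 log units; beyond the scatter) lying beyond the scatter, and the furthest is compound 1, with a 75-fold lower number from compound 1 to compound 3 (1.88 log units; beyond the scatter) also beyond the scatter.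

Compound 4 `O=C(O)CCCCCCOc1cc(-c2ccccc2)cc(-c2ccccc2)n1` differs from compound 3 by 2-carboxyethyl in place of 1-carboxyethyl on a saturated chain carbon, four bonds along the chain from an oxygen on an aromatic ring. The same atoms are kept but joined differently: the chain grows longer while its carboxy end is left unbranched, so compound 4 reads as the straight-chain relative of compound 2, extended further.

Among the compounds with values here, two measured steps bear on this. Lengthening the straight chain gave a 6.0-fold lower number from compound 1 to compound 2 (0.78 log units; beyond the scatter), a modest gain. Branching the chain end gave a 13-fold lower number from compound 2 to compound 3 (1.10 log units; beyond the scatter), a larger gain. Compound 4 keeps a longer chain but gives up the branch; the branch accounted for the larger of the two steps, so the change from compound 3 to compound 4 is expected to raise the number in this assay, though not all the way back to compound 2, as the extra chain length may offset part of the loss.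

Compound 4 is therefore estimated at 20 nM, within 5 nM to 80 nM, an expected step of a 5.0-fold higher number from compound 3 to compound 4 (0.70 log units; beyond the scatter).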

Compound 4, half-maximal inhibitory concentration: 25 nM
The estimate for compound 4 lay 1.3-fold (0.10 log units) below the measured number; the measured number falls inside the stated range.
By their numbers in this assay, from the lowest: compound 3; then compounds 4 and 2 (each within the scatter of the next); then compound 1.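

In this assay, the same atoms joined differently do not give the same result: 2-carboxyethyl in place of 1-carboxyethyl, on a saturated chain carbon four bonds along the chain from an oxygen on an aromatic ring, gives a 6.3-fold higher number from compound 3 to compound 4 (0.80 log units; beyond the scatter) and so shows that the low number of compound 3 depends on the branched arrangement and not on atom count alone. Further lengthening of the unbranched chain gives a 2.0-fold lower number from compound 2 to compound 4 (0.30 log units; within the scatter), which lies within the scatter, so compound 2 and compound 4 cannot be told apart, and the overall a 12-fold lower number from compound 1 to compound 4 (1.08 log units; beyond the scatter) shows no measurable gain over what compound 2 had already reached. Nothing measured here explains why the branched chain holds the lower number.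

From the compounds shown here alone, whether a longer chain that keeps the branch of 1-carboxyethyl would match or pass compound 3 remains open, as does the effect of an ethyl branch or a second methyl group on that same chain carbon. Going by these compounds, it is equally open whether a tetrazole could stand in for the carboxy group on the chain of compound 3.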